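The source may report more compounds than this note shows. Statements on the series, on what has been measured and on what is new or still open speak of the compounds shown alone.

Measured so far:
- compound 1, `COc1cc2cc(Oc3ccc(NC(=O)Nc4ccc(C)cc4)cc3)c(C)nc2cc1OC`: in a functional assay on HCT-15 cells (Homo sapiens) for inhibition, read by sulforhodamine B assay, with a stated time of 48 h, tested at 10 uM (a lower number here means a stronger effect, a higher number a weaker effect of the compound at the concentration tested), compound 1 gives 103%.
- compound 2, `COc1cc2cc(Oc3ccc(NC(=O)Nc4ccc(Cl)c(C(F)(F)F)c4)cc3)c(C)nc2cc1OC`: in this assay compound 2 gives 1.27%.

Compound 1 stands at the higher of the two numbers, meaning the weaker effect; its nearest neighbour is compound 2, reached by a number 101.7 percentage points lower from compound 1 to compound 2 (beyond the scatter). That single step is the only one recorded, and it shows that exchanging the group on the amide-type nitrogen can move the read-out a long way.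

Compound 3 is `COc1cc2cc(Oc3ccc(NC(=O)Nc4ccc(Cl)c(Cl)c4)cc3)c(C)nc2cc1OC`. It differs from compound 1 in one place: 3,4-dichlorophenyl in place of 4-methylphenyl on an amide-type nitrogen. The step from compound 1 to compound 2 bears on this change, since both replace the 4-methylphenyl with a phenyl carrying chlorine together with a further halogen-containing group, and that step was large. A step of similar size and in the same direction, toward a lower number and thus a stronger effect, is therefore expected for compound 3, as a number 95 percentage points lower from compound 1 to compound 3 (beyond the scatter), with some allowance for the two entering groups not being identical.

In this assay compound 3 is estimated to give 8%, expected to lie between 1% and 40%.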

Compound 3, a percentage reported as activity, at one concentration (the size of the read-out at that concentration, not a potency): 18.9%
Beside the measured number, compound 3's estimate is 10.9 percentage points below it; low and high end bracket the measured number.
By their numbers in this assay, from the lowest: compound 2; then compound 3; then compound 1.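

In this assay, replacing 4-methylphenyl with 3,4-dichlorophenyl on the amide-type nitrogen gives a number 84.1 percentage points lower from compound 1 to compound 3 (beyond the scatter), so a large drop at this position does not require a trifluoromethyl group. The two compounds with the stronger effects differ only in one group on an aromatic carbon, and putting chloro in place of trifluoromethyl gives a number 17.6 percentage points higher from compound 2 to compound 3 (beyond the scatter), a modest change next to the large step from the 4-methylphenyl compound. At this position, therefore, both replacements carrying chlorine greatly strengthen the effect at the tested concentration, while the exchange of trifluoromethyl for chloro tunes it only modestly, and no measurement here gives a reason for either change.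

The compounds shown leave open whether a single chlorine would be enough, as in 4-chlorophenyl, and what a nitrile or a methoxy group would do on the same aromatic carbon. They also leave open how these compounds would rank at other concentrations, since a single-concentration read-out is not a measure of potency.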